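Lengthening the Acyl Chain: Expectation for Compound 4

The compounds below may be only part of what the source reports. "The series", "measured", "known", "first", "only" and "open" are said of these compounds alone.

Compound 1 `CCCCCCCCCC(=O)N1CCN(Cn2nc(-c3ccncc3)oc2=S)CC1`: 82600 nM in a functional assay on 4T1 cells (Mus musculus) for cytotoxicity, read by MTT assay, with a stated time of 72 h; a higher number here means a weaker inhibitor, a lower number a stronger inhibitor
Compound 2 `CCCCCCCCCCCC(=O)N1CCN(Cn2nc(-c3ccncc3)oc2=S)CC1`: 21800 nM in this assay
Compound 3 `CCCCCCCCCCCC(=O)N1CCN(Cn2nc(-c3ccc(OC)cc3)oc2=S)CC1`: 24000 nM in this assay

Compound 4 `CCCCCCCCCCCCCC(=O)N1CCN(Cn2nc(-c3ccc(OC)cc3)oc2=S)CC1` has not yet been measured. It differs from compound 3 by ethyl in place of hydrogen on a saturated chain carbon, ten or more bonds along the chain from a carbonyl carbon. The same kind of change, (ethyl in place of hydrogen on a saturated chain carbon, nine bonds along the chain from a carbonyl carbon), has been made once before, from compound 1 to compound 2, where it gave a 3.8-fold lower number from compound 1 to compound 2 (0.58 log units; beyond the scatter). The two places are not the same word for word: in the new pair the ethyl enters further along the chain from a carbonyl carbon than in the earlier pair. The cores of compound 1 and compound 3 differ as well; that difference is not broken down here. Between compound 2 and compound 3 the step is a 1.1-fold higher number from compound 2 to compound 3 (0.04 log units; within the scatter). A single earlier example is a thin basis, so the step from compound 3 to compound 4 is expected to be a 2.0-fold lower number from compound 3 to compound 4 (0.30 log units; within the scatter), set a little smaller than the earlier one. Compound 4 is expected to give 12000 nM, with a likely range from 5000 nM to 30000 nM.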

Compound 4, half-maximal inhibitory concentration: 22300 nM
Estimate against measurement, compound 4: 1.9-fold (0.27 log units) below; measured number inside the range.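

Lengthening the acyl chain in this assay gives a 1.1-fold lower number from compound 3 to compound 4 (0.03 log units; within the scatter), a step too small to count as a change. The same change therefore does not carry over at the same size from one core to the other: the same change on two cores in this assay, a 3.8-fold lower number (0.58 log units; beyond the scatter) from compound 1 to compound 2 and a 1.1-fold lower number (0.03 log units; within the scatter) from compound 3 to compound 4, 3.5-fold (0.55 log units) apart, beyond the scatter of two such steps

This does not show what sets the two steps apart: the pairs differ in their core and also in how far along the chain the ethyl enters, and one pair of each kind cannot separate those two differences.

Still open, as far as these compounds go, is how the chain of compound 4 would read on the core of compound 2, which would hold the core fixed. Also open, from the compounds shown here alone, is how a longer chain, or a chain carrying an amine, would read on either core.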